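The compounds below may be only part of what the source reports. "The series", "measured", "known", "first", "only" and "open" are said of these compounds alone.

Measured compounds:
Compound 1, `CCCSc1nc(N)nc2c1ncn2/C=C1/CC1(CO)CO`: in an ADME assay on HFF cells (Homo sapiens) for cytotoxicity, with a stated time of 8 days (on this read-out lower numbers stand for higher toxicity in this test and higher numbers for lower toxicity in this test), compound 1 gives > 300000 nM, which is a limit of the assay.
Compound 2, `CCCCCCSc1nc(N)nc2c1ncn2/C=C1/CC1(CO)CO`: in this assay compound 2 gives > 300000 nM, also a limit.
Compound 3, `CSc1nc(N)nc2c1ncn2/C=C1/CC1(CO)CO`: in this assay compound 3 gives > 300000 nM, again a limit.

Compound 3 therefore stands where every measured compound stands, at the limit of > 300000 nM in this assay, at which 3 of the 3 values shown sit; no number separates it from the others. The next compound, compound 4, `C=CCOc1nc(N)nc2c1ncn2/C=C1/CC1(CO)CO`, differs from compound 3 in one place: allyloxy in place of methylsulfanyl on an aromatic carbon.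

The measured steps that touch the same position are a step that the two limits leave unreadable from compound 1 to compound 3 and a step that the two limits leave unreadable from compound 2 to compound 3, and the third step, a step that the two limits leave unreadable from compound 1 to compound 2, is of the same unreadable kind. None of them gives a direction or a size to carry over. The author thus expects no readable step in this assay, and the estimated step of a number no higher from compound 3 to compound 4 (the limit leaves the size open) reflects that. For compound 4 the expected value is 300000 nM, within a range from 100000 nM to 1000000 nM, most likely reported once more as a limit.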

Compound 4, half-maximal cytotoxic concentration: > 300000 nM
Compound 4: only a limit was reported (the forecaster's own chance of this, stated with the estimate: 85%); the middle value lies on the limit itself.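

In this assay, going by these compounds alone, compound 4 gives > 300000 nM, a limit of the assay, so no step from compound 1, compound 2 or compound 3 to compound 4 can be read: the limit of > 300000 nM in this assay, at which 4 of the 4 values shown sit. The compounds shown leave open whether allyloxy and the sulfanyl chains differ in this read-out at all.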